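The source may hold more compounds than are shown below. What is called first, only, known or untested is meant among the compounds shown, and "the series" means these compounds.

In a physicochemical assay for solubility, read by HPLC, in phosphate buffer, measured as kinetic solubility, at pH 7.4 (on this read-out higher numbers stand for higher solubility and lower numbers for lower solubility), compound 3 `CCC(=O)c1cc(-c2ccc(OC)cc2)n(-c2ccc(S(N)(=O)=O)cc2)c1C` gives 12800 nM. Compound 1 `CCC(=O)c1cc(-c2ccc(Cl)cc2)n(-c2ccc(S(=O)(=O)NC)cc2)c1C` gives 8700 nM, which is within the usual scatter of compound 3. Compound 2 `CCC(=O)c1cc(-c2ccc(Cl)cc2)n(-c2ccc(S(C)(=O)=O)cc2)c1C` gives 4800 nM, a lower number than compound 3 and one beyond the scatter.

The next molecule, compound 4 `CCC(=O)c1cc(-c2ccc(Cl)cc2Cl)n(-c2ccc(S(N)(=O)=O)cc2)c1C`, has 2,4-dichlorophenyl in place of 4-methoxyphenyl on an aromatic carbon. Among the measured compounds shown here, the only measured single change is a 1.8-fold lower number from compound 1 to compound 2 (0.26 log units; within the scatter), methyl in place of methylamino on a sulfonyl sulfur. For the measured compounds named here, that step lies elsewhere in the molecule, so no measured step tests this swap directly.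

The indirect evidence is thin. Compound 1 and compound 2 also carry chlorine on the aromatic group at this carbon, but they differ from compound 3 at the sulfonyl group too. Neither gives a number clearly above compound 3, so a modest drop in this assay seems the likelier outcome.

The expected change is a 3.2-fold lower number from compound 3 to compound 4 (0.51 log units; beyond the scatter). For compound 4 the estimated solubility is 4000 nM, within an expected range of 1200 nM to 10000 nM.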

Compound 4, solubility: 7700 nM
The estimate for compound 4 lay 1.9-fold (0.28 log units) below the measured number, and the stated range covers the measured number.
By their numbers in this assay, from the lowest: compounds 2, 4, 1 and 3 (each within the scatter of the next, the first and the last beyond it).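

Among the compounds shown here, this pair gives the first direct reading of a change at this position, the aromatic carbon next to the ring nitrogen, with the rest of the molecule held constant. In this assay, 2,4-dichlorophenyl in place of 4-methoxyphenyl gives a 1.7-fold lower number from compound 3 to compound 4 (0.22 log units; within the scatter), so the two compounds cannot be told apart in this measurement, even though one group carries two chlorines and the other a methoxy. No supporting measurement is available to explain this result.

Going by these compounds, it remains open what an amine or a carboxylic acid on this aromatic ring would do to the number, or a pyridine ring in its place. On these data alone, it is also open whether the same swap would give a similar step with methyl or methylamino on the sulfonyl sulfur.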